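Capping the pyrrolidine nitrogen: sulfonyl to amide

The source may hold more compounds than are shown below. What is called first, only, known or untested is meant among the compounds shown, and "the series" means these compounds.

Of the compounds shown here, three sharing one core have been measured in a functional assay on HCC827 cells (Homo sapiens) for antiproliferative activity, read by MTT assay, with a stated time of 72 h; a higher number here means a weaker inhibitor, a lower number a stronger inhibitor. Among the measured compounds shown here, compound 1 `CN1CCN(c2ccc(Nc3ncc4nc(Nc5ccc(F)cc5)n([C@H]5CCCNC5)c4n3)cc2)CC1` gives 38 nM, while compound 2 `CN1CCN(c2ccc(Nc3ncc4nc(Nc5ccc(F)cc5)n([C@H]5CCNC5)c4n3)cc2)CC1` gives 1220 nM; the step of a 32-fold higher number from compound 1 to compound 2 (1.51 log units; beyond the scatter) is the only single-point change measured here. Compound 3 `CN1CCN(c2ccc(Nc3ncc4nc(Nc5ccccc5)n([C@H]5CCN(S(C)(=O)=O)C5)c4n3)cc2)CC1` gives 17 nM, the lowest of the three numbers, with compound 1 nearest and compound 2 furthest. Compound 2 and compound 3 differ in more than one place, so their values are shown only side by side, not as a step.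

Compound 4 `CNC(=O)CN1CC[C@H](n2c(Nc3ccccc3)nc3cnc(Nc4ccc(N5CCN(C)CC5)cc4)nc32)C1` differs from compound 3 in one place: (methylcarbamoyl)methyl in place of methylsulfonyl on an amine nitrogen in a ring. For the measured compounds named here, no measured step touches this change, and nothing in the data speaks to replacing one cap on this nitrogen by another. The expectation for compound 4 must therefore rest on compound 3 alone, with wide uncertainty, and no step beyond the scatter is expected in either direction; the estimated step is a 1.8-fold higher number from compound 3 to compound 4 (0.25 log units; within the scatter). Compound 4 is thus expected to give about 30 nM, within the range 8 nM to 150 nM.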

Compound 4, half-maximal inhibitory concentration: 170 nM
For compound 4 the middle estimate is 5.7-fold (0.75 log units) below the measured one, outside the stated range (above it).
By their numbers in this assay, from the lowest: compound 3; then compound 1; then compound 4; then compound 2.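

In this assay, putting (methylcarbamoyl)methyl in place of methylsulfonyl on the amine nitrogen in the ring gives a 10-fold higher number from compound 3 to compound 4 (1.00 log units; beyond the scatter). Among the compounds shown here, this shows that the group on this nitrogen affects the read-out, which the one earlier step, a change of ring size, could not show. The entering group brings a hydrogen-bond donor and the leaving group has none, but nothing shown links that count, or any other difference between the two groups, to the size of this step.

The effect of capping itself cannot be read, since compound 2, with its free nitrogen, differs from compound 3 and compound 4 in more than one place. Also open, on these data alone, is whether the amide hydrogen or the chain matters here, which an acetyl, dimethylcarbamoylmethyl or carboxymethyl group on this nitrogen would help to separate.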